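The source may report more compounds than this note shows. Statements on the series, on what has been measured and on what is new or still open speak of the compounds shown alone.

Compound 1 `COc1nc(C)nc(/N=C/c2ccc(C)cc2)n1` is one of two compounds of the series tested in an ADME assay on Vero cells (Chlorocebus sabaeus) for cytotoxicity, read by MTT assay, with a stated time of 72 h; on this read-out lower numbers stand for stronger inhibition and higher numbers for weaker inhibition. In this assay compound 1 gives > 50 ug/mL, which is a limit of the assay rather than a measured number, the situation summarised by the limit of > 50 ug/mL in this assay, at which 1 of the 2 values shown sits. Going by the values given here, compound 2 `COc1nc(C)nc(/N=C/c2cccc([N+](=O)[O-])c2)n1` carries the entry "not determined" (no result reported) in this assay, so the series yields no second number and no measured step between compounds. Compound 3 `COc1nc(C)nc(/N=C/c2ccc(Cl)cc2)n1` differs from compound 1 by chloro in place of methyl on an aromatic carbon. Among the compounds with values here, with only a limit for compound 1 and no recorded step, there is no basis for expecting a shift in either direction; the working expectation is a step no larger than the usual scatter, with a fair chance that this assay again reports only a limit. On that basis compound 3 is estimated at 50 ug/mL, within 25 ug/mL to 100 ug/mL. This corresponds to an expected step of a number no higher from compound 1 to compound 3 (the limit leaves the size open).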

Compound 3, half-maximal inhibitory concentration: > 50 ug/mL
Compound 3 gave a limit, no number (the forecaster's own chance of this, stated with the estimate: 70%); the middle value lies on the limit itself.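

In this assay compound 3 gives > 50 ug/mL, a limit and not a number. Compound 1 also stands at a limit, so no step can be read between compound 1 and compound 3. On these data alone, whether chloro in place of methyl changes this read-out remains open.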